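Trifluoromethyl to hydrogen on the benzoyl of compound 3

The source may report more compounds than this note shows. Statements on the series, on what has been measured and on what is new or still open speak of the compounds shown alone.

Values in a functional assay on OVCAR-8 cells (Homo sapiens) for inhibition, read by sulforhodamine B assay, with a stated time of 48 h; a lower number here means that less compound is tolerated, a higher number that more compound is tolerated:
- Compound 1 `O=C(Nc1cccc(-n2cc(-c3ccncc3)c(-c3ccc(Cl)c(O)c3)n2)c1)Nc1cccc(C(F)(F)F)c1`: > 32500 nM
- Compound 2 `COc1cc(-c2nn(-c3cccc(NC(=O)Nc4cc(C(F)(F)F)cc(C(F)(F)F)c4)c3)cc2-c2ccncc2)ccc1Cl`: > 50000 nM
- Compound 3 `COc1cc(-c2nn(-c3cccc(NC(=O)c4cccc(C(F)(F)F)c4)c3)cc2-c2ccncc2)ccc1Cl`: > 50000 nM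

All three entries are limits of the assay and not numbers, so none of the compounds has an exact measured value. Compound 3 stands at the limit of > 50000 nM in this assay, at which 2 of the 3 values shown sit, and compound 2 shares that limit. No number therefore places compound 3 against the others.

The next compound is compound 4 `COc1cc(-c2nn(-c3cccc(NC(=O)c4ccccc4)c3)cc2-c2ccncc2)ccc1Cl`, which has not yet been measured. It carries hydrogen in place of trifluoromethyl on an aromatic carbon, so 3-(trifluoromethyl)phenyl becomes phenyl and the rest of the structure stays as in compound 3.

Among the compounds with values here, no pair of measured compounds gives a step to compare with this change. The expectation rests only on compound 3 at > 50000 nM, which is a limit. No change beyond the scatter is expected in this assay, and no direction can be favoured. The expected size is a number no higher from compound 3 to compound 4 (the limit leaves the size open). A result reported only as a limit would be the likeliest outcome. For compound 4 the estimated value is 50000 nM, with an expected range from 25000 nM to 100000 nM.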

Compound 4, concentration lethal to 50% of the cells: > 100000 nM
Compound 4 ended at the assay's limit (the forecaster's own chance of this, stated with the estimate: 80%); middle value at least 2.0-fold (0.30 log units) away from the limit.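

In this assay compound 4 gives > 100000 nM, which is a limit. Compound 3 gives > 50000 nM, also a limit. No step can be read between these two compounds. The compounds shown leave open whether replacing trifluoromethyl with hydrogen changes the result in this assay at all, as none of them has an exact value.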